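The source may hold more compounds than are shown below. What is called first, only, known or untested is meant among the compounds shown, and "the series" means these compounds.

Working notes on the series.

Of the compounds shown here, three have been measured in a functional assay on WM 266-4 cells (Homo sapiens) for inhibition, read by MTT assay, with a stated time of 24 h; a lower number here means a stronger inhibitor of growth, a higher number a weaker inhibitor of growth. Compound 1 `COc1ccc(C2CC(c3ccccc3)=NN2C(=O)c2ccc3c(c2)OCCO3)cc1` gives 8370 nM. Compound 2 `O=C(c1ccc2c(c1)OCCO2)N1N=C(c2ccccc2)CC1c1ccccc1` differs from compound 1 only by hydrogen in place of methoxy on an aromatic carbon; in this assay compound 2 gives 1370 nM, a step of a 6.1-fold lower number from compound 1 to compound 2 (0.79 log units; beyond the scatter). Compound 3 `COc1ccc(C2=NN(C(=O)C3COc4ccccc4O3)C(c3ccccc3F)C2)cc1` is built on a different core, and the difference between the two cores is not broken down here; in this assay compound 3 gives 5720 nM, which sits within the scatter of compound 1 and well above compound 2.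

Compound 4 `O=C(C1COc2ccccc2O1)N1N=C(c2ccccc2)CC1c1ccccc1F` has not yet been measured in this assay. It differs from compound 3 by hydrogen in place of methoxy on an aromatic carbon. This is the same change as the one from compound 1 to compound 2, made on the other core, and it occurs twice among the compounds shown. Nothing beyond that single measured pair supports a pattern, so the expectation for compound 4 rests on one observation only.

On that basis compound 4 is expected to give 1600 nM in this assay, a step of a 3.6-fold lower number from compound 3 to compound 4 (0.55 log units; beyond the scatter) that is estimated because the same change gave a 6.1-fold lower number from compound 1 to compound 2 (0.79 log units; beyond the scatter). The estimate for compound 4 is kept somewhat smaller than that earlier step, since a change measured once on a different core may not carry over fully, and the range from 600 nM to 4500 nM reflects that uncertainty.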

Compound 4, concentration for 50% growth inhibition: 1490 nM
The estimate for compound 4 lay 1.1-fold (0.03 log units) above the measured number; the measured number falls inside the stated range.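

In this assay, hydrogen in place of methoxy on the aromatic carbon gives a 3.8-fold lower number from compound 3 to compound 4 (0.58 log units; beyond the scatter), the same direction as on the core of compound 1. Set side by side, the two steps show no difference that can be told from the usual variation between repeated measurements: the same change on two cores in this assay, a 6.1-fold lower number (0.79 log units; beyond the scatter) from compound 1 to compound 2 and a 3.8-fold lower number (0.58 log units; beyond the scatter) from compound 3 to compound 4, 1.6-fold (0.20 log units) apart, within the scatter of two such steps. In this series, the change from 4-methoxyphenyl to phenyl therefore carries over from the core of compound 1 to the core of compound 3 in direction and, as far as the scatter allows, in size, but two pairs in a single assay do not show that it would hold on any further core, and they give no reason for the step or any comparison of the two cores.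

The compounds shown leave open whether the step reflects the removal of methoxy specifically or would also appear with other groups in the same place, such as an amine, a carboxylic acid or a longer alkoxy chain. They also leave open whether the same step would appear on a core other than these two or in a different cell line.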